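A few compounds are considered here, and "the series" means these few. Any claim that something is new, unique, unknown or untested is made for them only; others in the source may bear on it.

Of the compounds shown here, three built on one shared core have been tested in a functional assay on LNCaP cells (Homo sapiens) for cytotoxicity, read by MTT assay, with a stated time of 72 h; a lower number here means a stronger inhibitor, a higher number a weaker inhibitor. Compound 1 `CC1=C(/C=C/C(=O)/C=C/c2cccc(C(F)(F)F)c2)C(C)(C)CCC1O` gives 740 nM, compound 2 `CC1=C(/C=C/C(=O)/C=C/c2ccccc2F)C(C)(C)CCC1O` gives 2900 nM, and compound 3 `CC1=C(/C=C/C(=O)/C=C/c2cccc(F)c2)C(C)(C)CCC1O` gives 4400 nM. Compound 2 therefore stands second highest of the three numbers, with compound 3 within the scatter of it and compound 1 clearly lower. Compound 4 `CC1=C(/C=C/C(=O)/C=C/c2cccc(C(F)(F)F)c2F)C(C)(C)CCC1O` differs from compound 2 by trifluoromethyl in place of hydrogen on an aromatic carbon. Among the measured compounds shown here, one measured step bears directly on this change: a 5.9-fold higher number from compound 1 to compound 3 (0.77 log units; beyond the scatter), so the trifluoromethyl group went with the lower number. The other step, a 1.5-fold higher number from compound 2 to compound 3 (0.18 log units; within the scatter), lies within the scatter. A downward step of similar size is therefore expected, namely a 4.1-fold lower number from compound 2 to compound 4 (0.62 log units; beyond the scatter). Compound 4 is estimated at 700 nM, with a range from 250 nM to 2000 nM.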

Compound 4, half-maximal inhibitory concentration: 1100 nM
Beside the measured number, compound 4's estimate is 1.6-fold (0.20 log units) below it, within the range that was stated.
By their numbers in this assay, from the lowest: compounds 1 and 4 (each within the scatter of the next); then compounds 2 and 3 (each within the scatter of the next).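

In this assay, trifluoromethyl goes with a lower number even on a ring that already carries fluoro, where it sits ortho to that fluoro group (a 2.6-fold lower number from compound 2 to compound 4 (0.42 log units; beyond the scatter)). With trifluoromethyl already on the ring, the extra fluoro group cannot be told apart from hydrogen (a 1.5-fold higher number from compound 1 to compound 4 (0.17 log units; within the scatter)). Going by these compounds, whether a methoxy group, an amine or a carboxylic acid on this aromatic carbon would also go with a lower number stays open. No measurement shown here explains why either step has the size it has.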